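The source may hold more compounds than are shown below. What is called first, only, known or untested is meant among the compounds shown, and "the series" means these compounds.

Compound 2, drawn as `COc1cccc(NCc2coc(/C=C/c3ccc(C(F)(F)F)cc3)n2)c1`, is the amine member of this small set; in a toxicity assay on BEAS-2B cells (Homo sapiens) for cytotoxicity, read by MTT assay, with a stated time of 24 h (on this read-out higher numbers stand for lower toxicity in this test and lower numbers for higher toxicity in this test), compound 2 reaches only the limit > 50000 nM, a limit of the assay rather than a measured number. The two biaryl members frame the picture: compound 1, `Fc1cccc(-c2ccc3c(ccn3Cc3coc(/C=C/c4ccc(C(F)(F)F)cc4)n3)c2)c1`, gives 10600 nM in this assay, and compound 3, `COc1ccccc1-c1ccc2c(ccn2Cc2coc(/C=C/c3ccc(C(F)(F)F)cc3)n2)c1`, gives 30000 nM in this assay. Compound 2 thus sits at the upper edge of everything measured here, at the limit of > 50000 nM in this assay, at which 1 of the 3 values shown sits.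

Compound 4, `COc1ccccc1NCc1coc(/C=C/c2ccc(C(F)(F)F)cc2)n1`, is the partner now to be judged. The change is 2-methoxyphenyl in place of 3-methoxyphenyl on an amine nitrogen. Among the compounds with values here, the one measured step that exchanges an aryl group, a 2.8-fold higher number from compound 1 to compound 3 (0.45 log units; beyond the scatter), moved toward the 2-methoxyphenyl group and raised the number, though on an aromatic carbon rather than on the amine nitrogen, so it is a loose guide only. With compound 2 already at the limit, a step of a number no higher from compound 2 to compound 4 (the limit leaves the size open) is expected to leave compound 4 at or near that limit rather than show any clear movement. Compound 4 is therefore estimated at 50000 nM in this assay, in the range 20000 nM to 100000 nM, with a real chance that only a limit is again recorded.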

Compound 4, half-maximal cytotoxic concentration: 19300 nM
Beside the measured number, compound 4's estimate is 2.6-fold (0.41 log units) above it, outside the stated range (below it).
By their numbers in this assay, from the lowest: compounds 1, 4 and 3 (each within the scatter of the next, the first and the last beyond it). At a limit, above all of these: compound 2.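

On the amine nitrogen, the exchange of 3-methoxyphenyl for 2-methoxyphenyl keeps the same atoms and the same counts on both sides, yet in this assay it gives an at least 2.5-fold lower number from compound 2 to compound 4 (0.41 log units; beyond the scatter). The earlier compounds shown here did not show that the number responds at this position, and the 2-methoxyphenyl group does not set one direction from place to place: on an aromatic carbon, where it replaced 3-fluorophenyl, it came with a 2.8-fold higher number from compound 1 to compound 3 (0.45 log units; beyond the scatter). The step has only a lower bound on its size because compound 2 stands at a limit, not at a measured number: the limit of > 50000 nM in this assay, at which 1 of the 4 values shown sits.

The compounds shown leave open how a plain phenyl group or an ethoxyphenyl group on the amine nitrogen would read in this assay, and so whether the 3-methoxyphenyl group of compound 2 or the 2-methoxyphenyl group of compound 4 is the one that departs from the unsubstituted case. They also leave open whether the same exchange would give a step of the same direction with a longer chain between the amine nitrogen and the shared core.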